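Ethoxy for methyl on the core: outlook for compound 3

The source may hold more compounds than are shown below. What is called first, only, known or untested is meant among the compounds shown, and "the series" means these compounds.

Compound 1 `Cc1cc(COc2cccc(C#N)c2)nc(-c2ccccn2)n1` gives 2510 nM in a functional assay on cells for antagonist activity at Free fatty acid receptor 1 (Homo sapiens), read by TR-FRET and inositol phosphate accumulation, with a stated time of 2 h; on this read-out higher numbers stand for weaker inhibition and lower numbers for stronger inhibition. Compound 2 `Cc1cc(COc2cccc(F)c2)nc(-c2ccccn2)n1` gives 794 nM in this assay. Within the data shown here, the one measured step, a 3.2-fold lower number from compound 1 to compound 2 (0.50 log units; beyond the scatter), concerns the fluoro-for-cyano exchange at a different site and leaves the core untouched. Compound 2 stands with the lower of the two numbers, compound 1 lying beyond the scatter above it. Compound 3 `CCOc1cc(COc2cccc(F)c2)nc(-c2ccccn2)n1` differs from compound 2 by ethoxy in place of methyl on an aromatic carbon of the core, next to the ring nitrogen and opposite the ring nitrogen. Among the measured compounds shown here, no measured step addresses this position, so the step from compound 1 to compound 2 offers no direct guide beyond showing modest shifts are typical here. The expected step of a 1.0-fold higher number from compound 2 to compound 3 (0.00 log units; within the scatter) is accordingly small, within or near the scatter, with wide uncertainty. Compound 3 is estimated at 800 nM in this assay, with a range from 250 nM to 2500 nM.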

Compound 3, half-maximal inhibitory concentration: 251 nM
Compound 3: the middle estimate sits 3.2-fold (0.50 log units) above what was measured; measured number inside the range.
By their numbers in this assay, from the lowest: compound 3; then compound 2; then compound 1.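

In this assay the methyl position on the core turns out to be responsive: ethoxy in place of methyl gives a 3.2-fold lower number from compound 2 to compound 3 (0.50 log units; beyond the scatter). Among these compounds, this is the first reading at this aromatic carbon, and it shows that going from 1 heavy atom to 3, with an oxygen among them, lowers the number rather than raising it. Nothing measured here bears on what lies behind the step.

As far as these compounds go, whether the oxygen or the added length carries the step stays open: methoxy or ethyl at this carbon would separate the two, and a longer alkoxy chain or an amine would show how far the position tolerates change. Also open, from the compounds shown here alone, is whether ethoxy gives a similar step alongside the nitrile of compound 1 instead of the fluoro of compound 3.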